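Replacing the Bromophenyl Arm of Compound 2 with a Chlorohydroxyphenyl

The compounds below may be only part of what the source reports. "The series", "measured", "known", "first", "only" and "open" are said of these compounds alone.

Of the compounds shown here, three built on one shared core have been tested in a functional assay on HT-1080 cells (Homo sapiens) for cytotoxicity, read by MTT assay, with a stated time of 72 h; on this read-out higher numbers stand for weaker inhibition and lower numbers for stronger inhibition. Compound 1 `COc1cccc(/C=C2\CCC/C(=C\c3ccccc3Br)C2=O)c1OC` gives 10800 nM. Compound 2 `COc1cccc(/C=C2\CCC/C(=C\c3cccc(Br)c3)C2=O)c1OC` gives 12200 nM. Compound 3 `COc1cccc(/C=C2\CCC/C(=C\c3cccc(OC)c3OC)C2=O)c1` gives 9900 nM. On these numbers compound 2 stands highest, but both neighbours lie within the scatter of it: the step of a 1.1-fold higher number from compound 1 to compound 2 (0.05 log units; within the scatter) and the step of a 1.2-fold lower number from compound 2 to compound 3 (0.09 log units; within the scatter) are small, as is the step of a 1.1-fold lower number from compound 1 to compound 3 (0.04 log units; within the scatter). In other words, every variation tried so far on that aryl group has left the read-out essentially unchanged.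

Compound 4 `COc1cccc(/C=C2\CCC/C(=C\c3ccc(O)c(Cl)c3)C2=O)c1OC` has not yet been measured. Relative to compound 2 it carries 3-chloro-4-hydroxyphenyl in place of 3-bromophenyl on a double-bonded chain carbon bound to a double-bonded ring carbon. Among the compounds with values here, two measured steps bear on this change. One is the exchange of bromo for methoxy on an aromatic carbon, a 1.2-fold lower number from compound 2 to compound 3 (0.09 log units; within the scatter); the other is the move from 2-bromophenyl to 3-bromophenyl, a 1.1-fold higher number from compound 1 to compound 2 (0.05 log units; within the scatter). Neither moved the number beyond the scatter. Within the data shown here, no measured compound carries a hydroxy or a chloro group on this ring, so that part of the change has no precedent here. The expectation is therefore that compound 4 sits close to compound 2, with a 1.1-fold lower number from compound 2 to compound 4 (0.04 log units; within the scatter) expected to be no step beyond the scatter. Compound 4 is estimated at 11000 nM, with a range from 5000 nM to 25000 nM.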

Compound 4, half-maximal inhibitory concentration: 14300 nM
Compound 4: middle estimate off by 1.3-fold (0.11 log units), on the low side, and the stated range covers the measured number.
By their numbers in this assay, from the lowest: compounds 3, 1, 2 and 4 (each within the scatter of the next).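

In this assay, placing 3-chloro-4-hydroxyphenyl on a double-bonded chain carbon bound to a double-bonded ring carbon leaves the read-out within the scatter of all three earlier compounds: a 1.2-fold higher number from compound 2 to compound 4 (0.07 log units; within the scatter), a 1.3-fold higher number from compound 1 to compound 4 (0.12 log units; within the scatter) and a 1.4-fold higher number from compound 3 to compound 4 (0.16 log units; within the scatter). Compound 4 is the only compound shown whose aryl group carries a hydroxy or a chloro group, and the only one with a hydrogen-bond donor there, so the flat picture at this position now extends to a change in two features of the ring, and not just to the bromo and methoxy variations. No measurement bears on why the number stays so close across these aryl groups.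

The compounds shown leave open whether the hydroxy and chloro groups of compound 4 would each give a similar number alone, as no compound here carries one without the other. They also leave open whether this position would stay as flat with something other than a substituted phenyl there, such as an amine, a carboxylic acid or a longer chain.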